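Notes: aryl swap from compound 2 to compound 3

The compounds below may be only part of what the source reports. "The series", "measured", "known", "first", "only" and "open" are said of these compounds alone.

- compound 1 `C[C@H]1CC[C@@H]2[C@@H](OC(=O)[C@]23CC(c2c(Cl)cccc2Cl)=NO3)[C@]2(C)C(=O)C=C[C@@]12O` gives 43000 nM in a functional assay on SW-620 cells (Homo sapiens) for cytotoxicity, read by sulforhodamine B assay, with a stated time of 48 h; a higher number here means a weaker inhibitor, a lower number a stronger inhibitor
- compound 2 `C[C@H]1CC[C@@H]2[C@@H](OC(=O)[C@]23CC(c2ccc(N(C)C)cc2)=NO3)[C@]2(C)C(=O)C=C[C@@]12O` gives 5100 nM in this assay

Within the data shown here, of the two compounds measured so far, compound 2 stands lowest, and the higher number of compound 1 lies beyond the scatter from it. Compound 3 `COc1ccc(C2=NO[C@]3(C2)C(=O)O[C@@H]2[C@H]3CC[C@H](C)[C@]3(O)C=CC(=O)[C@@]23C)cc1OC` has not yet been measured. Its change from compound 2 is 3,4-dimethoxyphenyl in place of 4-(dimethylamino)phenyl on a carbon with a double bond to nitrogen (3,4-dimethoxyphenyl in place of 4-(dimethylamino)phenyl). The exchange falls on a carbon with a double bond to nitrogen of the five-membered non-aromatic ring, and the shared core stays as it is.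

Among the measured compounds shown here, one measured step bears on this place: an 8.4-fold lower number from compound 1 to compound 2 (0.93 log units; beyond the scatter) (a modest step). For the measured compounds named here, it shows that the number can move with the aryl group here, but no measured compound carries a dimethoxy-substituted ring. A smaller step than that one is expected, towards a higher number, and a step within the scatter remains possible. The estimated step is a 2.2-fold higher number from compound 2 to compound 3 (0.33 log units; beyond the scatter) in this assay on this reading. For compound 3 the expected value is 11000 nM in this assay (3500 nM to 32000 nM).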

Compound 3, half-maximal inhibitory concentration: 86000 nM
Estimate against measurement, compound 3: 7.8-fold (0.89 log units) below; measured number outside the range, above it.
By their numbers in this assay, from the lowest: compound 2; then compounds 1 and 3 (each within the scatter of the next).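

Notes on the aryl position: in this assay the lower number of compound 2 does not carry over to another electron-neutrally unspecified ring.

Correction to the line above, final notes: in this assay the lower number of compound 2 does not carry over to 3,4-dimethoxyphenyl, as shown by a 17-fold higher number from compound 2 to compound 3 (1.23 log units; beyond the scatter) on the carbon with a double bond to nitrogen. Against this, a 2.0-fold higher number from compound 1 to compound 3 (0.30 log units; within the scatter) means that 3,4-dimethoxyphenyl and 2,6-dichlorophenyl cannot be told apart here, so among the three aryl groups shown only 4-(dimethylamino)phenyl stands apart, and the earlier step from the dichlorinated ring reads as tied to that group rather than to any replacement of 2,6-dichlorophenyl. Nothing on hand gives a reason for the separation of compound 2 from the other two.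

From the compounds shown here alone, whether the lower number belongs to the dimethylamino group itself or to some broader feature of the ring stays open. A plain phenyl, a 4-aminophenyl and a 4-methoxyphenyl group on the same carbon, with the shared core unchanged, would help to separate these readings.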